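This account rests on a few compounds, and the source may have more. Where it says the series, first, only, none or still open, it means among the compounds named here.

Working notes on the series. In a functional assay on PC-3 cells (Homo sapiens) for cytotoxicity, read by MTT assay, with a stated time of 48 h (a higher number here means a weaker inhibitor, a lower number a stronger inhibitor), compound 1 `Cc1cccc(/C=C/[C@](C)(O)CC[C@@H]2[C@@]3(C)CCCC(C)(C)[C@@H]3CC[C@@]2(C)O)c1C` gives 3500 nM, the highest of the two numbers in hand. Among the measured compounds shown here, compound 2 `Cc1cccc(C)c1/C=C/[C@](C)(O)CC[C@@H]1[C@@]2(C)CCCC(C)(C)[C@@H]2CC[C@@]1(C)O` gives 278 nM in this assay, and the only measured step, a 13-fold lower number from compound 1 to compound 2 (1.10 log units; beyond the scatter), shows that the aryl pattern shifts the number strongly. Compound 3 `CC1(C)CCC[C@]2(C)[C@@H](CC[C@@](C)(O)/C=C/c3ccc(F)cc3)[C@](C)(O)CC[C@@H]12` carries 4-fluorophenyl in place of 2,3-dimethylphenyl on a double-bonded chain carbon bound to a double-bonded chain carbon. For the measured compounds named here, no measured step covers a fluorophenyl, so the direction of the step is uncertain; a drop in the number is expected to be likelier than a rise, given the step of a 13-fold lower number from compound 1 to compound 2 (1.10 log units; beyond the scatter). Compound 3 is estimated at 1800 nM in this assay, range 400 nM to 8000 nM, a step of a 1.9-fold lower number from compound 1 to compound 3 (0.29 log units; within the scatter).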

Compound 3, half-maximal inhibitory concentration: 82 nM
For compound 3 the middle estimate is 22-fold (1.34 log units) above the measured one; measured number outside the range, below it.
By their numbers in this assay, from the lowest: compound 3; then compound 2; then compound 1.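

In this assay, 4-fluorophenyl on a double-bonded chain carbon bound to a double-bonded chain carbon gives a 43-fold lower number from compound 1 to compound 3 (1.63 log units; beyond the scatter) and a 3.4-fold lower number from compound 2 to compound 3 (0.53 log units; beyond the scatter). Compound 3 therefore has the lowest number of the three, with both steps beyond the scatter, and neither dimethylphenyl pattern is needed for a low number at this position. Nothing measured here bears on the reason for this change. The compounds shown do not separate the gain of fluorine from the loss of the methyl groups; an unsubstituted phenyl or a 4-methylphenyl would do so. Going by these compounds, how an amine or a carboxylic acid on this ring would behave also remains open.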